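Epoxide lactone versus hydroxy ester: a methyl homologation

The source may hold more compounds than are shown below. What is called first, only, known or untested is meant among the compounds shown, and "the series" means these compounds.

Measured so far:
- compound 1 `CCCCC(C)C[C@]1(CC)O[C@H]1[C@]1(CC)C=CC(=O)O1`: in a functional assay on K562 cells (Homo sapiens) for cytotoxicity, read by MTT assay, with a stated time of 72 h (on this read-out higher numbers stand for weaker inhibition and lower numbers for stronger inhibition), compound 1 gives only a limit, > 50000 nM.
- compound 2 `CCCCC(C)CC(O)(/C=C(/CC)[C@@H](O)CC(=O)OC)CC`: in this assay compound 2 gives 23800 nM.
- compound 3 `CCCCC(CC)CC(O)(/C=C(/CC)[C@@H](O)CC(=O)OC)CC`: in this assay compound 3 gives 20000 nM.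

Compound 4 `CCCCC(CC)C[C@]1(CC)O[C@H]1[C@]1(CC)C=CC(=O)O1` has not been measured. It differs from compound 1 by methyl in place of hydrogen on a saturated chain carbon, three bonds along the chain from a saturated ring carbon. The same kind of change separates the two hydroxy esters, (methyl in place of hydrogen on a saturated chain carbon, four bonds along the chain from a double-bonded chain carbon and an oxygen on a saturated carbon), though the surroundings differ: in that pair the place is four bonds along the chain from a double-bonded chain carbon and an oxygen on a saturated carbon, whereas in compound 4 it is three bonds along the chain from a saturated ring carbon. The measured step is a 1.2-fold lower number from compound 2 to compound 3 (0.08 log units; within the scatter). The difference between the core of compound 1 and the core of compound 2 is not broken down here.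

For compound 4 the expected step in this assay is a step that the limit leaves unreadable from compound 1 to compound 4, resting on the measured step of a 1.2-fold lower number from compound 2 to compound 3 (0.08 log units; within the scatter). Because compound 1 sits at the limit of > 50000 nM in this assay, at which 1 of the 3 values shown sits, compound 4 is also expected to return only a limit. The estimate for compound 4 is 70000 nM, between 30000 nM and 200000 nM.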

Compound 4, half-maximal inhibitory concentration: > 100000 nM
Compound 4: no number, only a limit; the forecaster's own chance of this, stated with the estimate: 80%; middle value at least 1.4-fold (0.15 log units) from the limit.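

In this assay compound 4 gives only a limit, > 100000 nM. Among these compounds, compound 1 also gives only a limit, > 50000 nM, so no step between compound 1 and compound 4 can be read. The compounds shown leave open whether the change from 1-methylpentyl to 1-ethylpentyl alters the read-out at all on the core of compound 1.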